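The source may report more compounds than this note shows. Statements on the series, on what has been measured and on what is new or still open speak of the compounds shown alone.

In a functional assay on MC-38 cells (Mus musculus) for antiproliferative activity (a higher number here means a weaker inhibitor, a lower number a stronger inhibitor), compound 1 (`COc1ccc(S(=O)(=O)Nc2cccc3cc[nH]c23)cc1`) gives 1.5 ug/mL and compound 2 (`Cc1ccc(S(=O)(=O)Nc2cccc3cc[nH]c23)cc1`) gives 2.4 ug/mL. These two values lie within the scatter of each other, so compound 2 cannot be separated from compound 1 on the numbers available. Compound 3 (`O=S(=O)(Nc1cccc2cc[nH]c12)c1ccc(Cl)cc1`) has chloro in place of methyl on an aromatic carbon of compound 2: chloro in place of methyl on an aromatic carbon. Going by the values given here, only one measured step bears on this change, a 1.6-fold higher number from compound 1 to compound 2 (0.20 log units; within the scatter), where methyl replaces methoxy at the same place. Among the compounds with values here, no measured compound before compound 3 carries chloro, so that single step is only a rough guide. On this evidence, no step beyond the scatter is expected in this assay, in either direction. The expected step is a 1.2-fold lower number from compound 2 to compound 3 (0.08 log units; within the scatter). For compound 3 the estimated value is 2 ug/mL, with an expected range from 0.9 ug/mL to 4.5 ug/mL.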

Compound 3, half-maximal inhibitory concentration: 7 ug/mL
The estimate for compound 3 lay 3.5-fold (0.54 log units) below the measured number, outside the stated range (above it).
By their numbers in this assay, from the lowest: compounds 1 and 2 (each within the scatter of the next); then compound 3.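

This position is less forgiving than the first two compounds suggested: methoxy and methyl could not be told apart at the aromatic carbon para to a large group, but chloro there gives a real change in this assay (a 2.9-fold higher number from compound 2 to compound 3 (0.46 log units; beyond the scatter) and a 4.7-fold higher number from compound 1 to compound 3 (0.67 log units; beyond the scatter)). Compound 3 is therefore the weakest inhibitor of the three, even though methyl and chloro each add a single heavy atom and neither brings a hydrogen-bond donor or acceptor. Nothing available explains this loss of activity.

As far as these compounds go, whether the loss is specific to chloro stays open, and fluoro or bromo at this place would help to show that. From the compounds shown here alone, it is also open how a more different group, such as an amine or a carboxylic acid, would fare here.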